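The compounds below may be only part of what the source reports. "The series", "measured", "known", "first", "only" and "open" are said of these compounds alone.

Compounds measured in a functional assay on CHO cells for antagonist activity at transient receptor potential cation channel subfamily V member 1 (Rattus norvegicus); a lower number here means a stronger inhibitor, a higher number a weaker inhibitor:
- compound 1 `CC(C)(C)c1ccc(CNC(=O)C2(c3ccc(NS(C)(=O)=O)cc3)CC2)cc1`: 1770 nM
- compound 2 `CC(NC(=O)/C=C/c1ccc(C(C)(C)C)cc1)c1ccc(NS(C)(=O)=O)c(F)c1`: 23.9 nM
- compound 3 `CC(C(=O)NCc1ccc(Br)cc1)c1ccc(NS(C)(=O)=O)c(F)c1`: 250 nM

Among these three numbers in this assay, compound 3 holds the second highest. Its nearest neighbour is compound 1, whose number is higher by a margin beyond the usual scatter; its furthest is compound 2, whose number is lower, again by a margin beyond the scatter. No pair of these compounds differs in only one place, so none of the gaps between them can be read as the effect of a single change.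

The step of interest leads from compound 3 to compound 4 `CC(C(=O)NCc1ccc(C2C=CCC2)cc1)c1ccc(NS(C)(=O)=O)c(F)c1`. The change is cyclopent-2-en-1-yl in place of bromo on an aromatic carbon, para to a large group, with the rest of the molecule left as it is.

Within the data shown here, no measured step offers a direct precedent for this exchange. The account therefore expects only a modest move in this assay, more likely toward a lower number than a higher one, and possibly within the scatter. Compound 4 is estimated at 150 nM, with a range from 40 nM to 600 nM. This expected step corresponds to a 1.7-fold lower number from compound 3 to compound 4 (0.22 log units; within the scatter).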

Compound 4, inhibition constant: 15 nM
Estimate against measurement, compound 4: 10-fold (1.00 log units) above; measured number outside the range, below it.
By their numbers in this assay, from the lowest: compounds 4 and 2 (each within the scatter of the next); then compound 3; then compound 1.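

In this assay, cyclopent-2-en-1-yl in place of bromo on the aromatic carbon para to a large group gives a 17-fold lower number from compound 3 to compound 4 (1.22 log units; beyond the scatter), a large step beyond the scatter and the only gap in this set that can be read as the effect of a single change. It shows that this position takes a ring of five carbon atoms with one double bond in place of a single bromine, and that the number falls rather than rises with this exchange, although no hydrogen-bond donor or acceptor enters or leaves. Nothing measured here accounts for the size of this step.

On these data alone, what a saturated cyclopentyl or a cyclohexyl would give on this aromatic carbon remains open, and with it whether the double bond or the ring itself carries the step. This is also a single pair, so whether the same exchange gives a step of like size on a different core, such as that of compound 1, is open too.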